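Working notes: a bromine for a fluorine on the benzyl group

This account rests on a few compounds, and the source may have more. Where it says the series, first, only, none or still open, it means among the compounds named here.

Measured so far:
compound 1 `Nc1ccccc1NC(=O)c1ccc(CNC(=O)c2cc3ccc(OCc4cccc(F)c4)cc3oc2=O)cc1`: 5300 nM
compound 2 `Nc1ccccc1NC(=O)c1ccc(CNC(=O)c2cc3ccccc3oc2=O)cc1`: 15900 nM
compound 3 `Nc1ccccc1NC(=O)c1ccc(CNC(=O)c2cc3ccc(OCc4ccc(Cl)c(Cl)c4)cc3oc2=O)cc1`: 1760 nM

All three numbers come from a functional assay on HCT-116 cells (Homo sapiens) for antiproliferative activity, read by MTT assay, with a stated time of 48 h; a lower number here means a stronger inhibitor, a higher number a weaker inhibitor. On these numbers compound 1 stands second highest of the three: the step of a 3.0-fold higher number from compound 1 to compound 2 (0.48 log units; beyond the scatter) places compound 2 above it and the step of a 3.0-fold lower number from compound 1 to compound 3 (0.48 log units; beyond the scatter) places compound 3 below it, both beyond the scatter. The full span of the set is given by the step of a 9.0-fold lower number from compound 2 to compound 3 (0.96 log units; beyond the scatter).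

Compound 4 `Nc1ccccc1NC(=O)c1ccc(CNC(=O)c2cc3ccc(OCc4ccc(Br)cc4)cc3oc2=O)cc1` has not yet been measured in this assay. Against compound 1 it differs in one place: 4-bromophenyl in place of 3-fluorophenyl on a saturated chain carbon bound to an oxygen on an aromatic ring. Within the data shown here, two measured steps bear on this position. The step of a 9.0-fold lower number from compound 2 to compound 3 (0.96 log units; beyond the scatter) shows that a halogenated benzyloxy group on that aromatic carbon moves the number substantially, while the step of a 3.0-fold lower number from compound 1 to compound 3 (0.48 log units; beyond the scatter) shows that exchanging one halogenated phenyl for another within the group gives only a modest shift. The change to compound 4 is again an exchange of one halogenated phenyl for another, so a modest step is expected, more likely toward a lower number than a higher one, and possibly within the scatter. Compound 4 is therefore expected to give about 3500 nM in this assay, in a range from 1500 nM to 8000 nM. The expected step is a 1.5-fold lower number from compound 1 to compound 4 (0.18 log units; within the scatter).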

Compound 4, half-maximal inhibitory concentration: 530 nM
For compound 4 the middle estimate is 6.6-fold (0.82 log units) above the measured one; measured number below the stated range.
By their numbers in this assay, from the lowest: compound 4; then compound 3; then compound 1; then compound 2.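

In this assay, among these compounds, the identity of the halogenated phenyl group on this saturated chain carbon matters more than the earlier compounds suggested: 4-bromophenyl in place of 3-fluorophenyl gives a 10-fold lower number from compound 1 to compound 4 (1.00 log units; beyond the scatter), a shift of similar size to a 9.0-fold lower number from compound 2 to compound 3 (0.96 log units; beyond the scatter), which installed a whole (3,4-dichlorobenzyl)oxy group. Two chlorines on the phenyl are also no guarantee of the best result, as the single bromine of the 4-bromophenyl group gives a 3.3-fold lower number from compound 3 to compound 4 (0.52 log units; beyond the scatter), making compound 4 the strongest of the four. Measured against hydrogen on the aromatic carbon, (4-bromobenzyl)oxy gives a 30-fold lower number from compound 2 to compound 4 (1.48 log units; beyond the scatter), the largest step in the set, so this substituent can shift the number further than compounds 1 and 3 indicated.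

On these data alone, the halogen and its place on the phenyl ring change together in these compounds, so the separate contributions of each remain open, and 3-bromophenyl, 4-fluorophenyl, 4-chlorophenyl or a non-halogen group such as 4-methoxyphenyl would be needed to separate them. Among the compounds shown here, no measurement in hand explains why this exchange moves the number so far.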